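The source may report more compounds than this note shows. Statements on the series, on what has been measured and on what is new or still open speak of the compounds shown alone.

Measured so far, cytotoxicity on pancreatic cancer cells:
compound 1, `Cc1nc(-c2cccnc2)sc1-c1nnc(Cc2ccccc2)o1`; in an ADME assay on PANC-1 cells (Homo sapiens) for cytotoxicity, read by MTT assay (a lower number here means that less compound is tolerated, a higher number that more compound is tolerated), compound 1 gives > 100 ug/mL, a limit.
compound 2, `Cc1nc(-c2cccnc2)sc1-c1nnc(-c2ccccc2Cl)o1`; in this assay compound 2 gives > 100 ug/mL, a limit.
compound 3, `Cc1nc(-c2cccnc2)sc1-c1nnc(-c2ccccc2)o1`; in this assay compound 3 gives > 100 ug/mL, a limit.

Compound 3 stands at the limit of > 100 ug/mL in this assay, at which 3 of the 3 values shown sit, so its place among the three is not resolved. Compound 4, `Cc1nc(-c2cccnc2)sc1-c1nnc(-c2ccc(Cl)cc2)o1`, differs from compound 3 by chloro in place of hydrogen on an aromatic carbon. Within the data shown here, the steps that bear on this are a step that the two limits leave unreadable from compound 2 to compound 3, which moves a chloro on the same ring at another position, and a step that the two limits leave unreadable from compound 1 to compound 3; both are unreadable, so no step size can be drawn from them. Compound 4 is therefore expected to sit at the limit again, with a step that the limit leaves unreadable from compound 3 to compound 4 that is not expected to exceed the scatter. The estimate for compound 4 is 150 ug/mL, within 70 ug/mL to 400 ug/mL.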

Compound 4, half-maximal cytotoxic concentration: > 100 ug/mL
Compound 4 was reported as a limit (the forecaster's own chance of this, stated with the estimate: 85%); the middle value does not contradict the limit.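

No step can be read among compound 1, compound 2, compound 3 and compound 4, as all four share one limit: the limit of > 100 ug/mL in this assay, at which 4 of the 4 values shown sit.
Going by these compounds, whether these four compounds differ at all in this assay remains open.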